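The source may hold more compounds than are shown below. What is called first, only, known or untested is meant among the compounds shown, and "the series" means these compounds.

Measured in a functional assay on T47D cells (Homo sapiens) for cytotoxicity, read by MTT assay, with a stated time of 48 h; on this read-out lower numbers stand for stronger inhibition and higher numbers for weaker inhibition:
- Compound 1 `COc1cc(-n2c(-c3ccccc3)csc2=S)cc(OC)c1OC`: 31.6 ug/mL
- Compound 2 `COc1cc(-n2c(-c3ccc(Cl)cc3)csc2=S)cc(OC)c1OC`: > 100 ug/mL, a limit of the assay
- Compound 3 `COc1cc(-n2c(-c3ccc(Cl)cc3Cl)csc2=S)cc(OC)c1OC`: 43.4 ug/mL

Compound 3 stands level with compound 1, with a 1.4-fold higher number from compound 1 to compound 3 (0.14 log units; within the scatter). Compound 4 `COc1cc(-n2c(-c3ccc(O)cc3)csc2=S)cc(OC)c1OC` carries 4-hydroxyphenyl in place of 2,4-dichlorophenyl on an aromatic carbon.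

For the measured compounds named here, no measured step introduces a hydroxy group, so the evidence is indirect. Two chloro in place of hydrogen steps, an at least 3.1-fold higher number from compound 1 to compound 2 (0.50 log units; beyond the scatter) and an at least 2.3-fold lower number from compound 2 to compound 3 (0.36 log units; beyond the scatter), lie beyond the scatter and run in opposite directions, so the effect of chloro depends on the compound. The closest comparison is compound 1, which lacks both chloro groups, and its a 1.4-fold higher number from compound 1 to compound 3 (0.14 log units; within the scatter) stays within the scatter. On that basis, no step beyond the scatter is expected in this assay, although a weaker result remains possible.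

The expected change is a 1.1-fold lower number from compound 3 to compound 4 (0.04 log units; within the scatter). For compound 4 the estimated value is 40 ug/mL, with an expected range from 15 ug/mL to 100 ug/mL.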

Compound 4, half-maximal inhibitory concentration: 26.4 ug/mL
For compound 4 the middle estimate is 1.5-fold (0.18 log units) above the measured one; the measured number falls inside the stated range.
By their numbers in this assay, from the lowest: compounds 4, 1 and 3 (each within the scatter of the next). At a limit, above all of these: compound 2.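

In this assay, 4-hydroxyphenyl on the aromatic carbon next to the ring nitrogen stays level with both the unsubstituted phenyl, a 1.2-fold lower number from compound 1 to compound 4 (0.08 log units; within the scatter), and 2,4-dichlorophenyl, a 1.6-fold lower number from compound 3 to compound 4 (0.22 log units; within the scatter), so this position accepts a hydrogen-bond donor without a step beyond the scatter. Compound 2 alone stands apart, and its value is a limit, not a number: the limit of > 100 ug/mL in this assay, at which 1 of the 4 values shown sits. Against that limit, hydroxy in place of chloro gives an at least 3.7-fold lower number from compound 2 to compound 4 (0.57 log units; beyond the scatter), which makes the 4-chlorophenyl of compound 2 the exception among the four compounds.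

On these data alone, whether an amine or a carboxylic acid in the same place on the phenyl ring would stay level with compound 4 remains open. The compounds shown also leave open whether any of these values holds in cells other than T47D.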